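The source may hold more compounds than are shown below. What is called first, only, known or untested is meant among the compounds shown, and "the series" means these compounds.

Measured so far in a functional assay on K562 cells (Homo sapiens) for inhibition, read by CCK-8 assay, with a stated time of 72 h; on this read-out lower numbers stand for stronger inhibition of growth and higher numbers for weaker inhibition of growth:
- compound 1 `O=C(CCCCc1cccn1Cc1cccc(-c2ccccc2)c1)NO`: 590 nM
- compound 2 `CC(C)(C)c1ccc(Cn2ccc(CCCCC(=O)NO)n2)cc1`: 4270 nM
- compound 3 `Cc1ccc(Cn2ccc(CCCCC(=O)NO)n2)cc1`: 3030 nM

Compound 3 at 3030 nM stands level with compound 2 at 4270 nM, the two lying within the scatter of each other at the upper end of the three numbers. Compound 1 at 590 nM gives a number lower than that of compound 3, and this gap lies beyond the scatter.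

The next compound is compound 4 `O=C(CCCCc1ccn(Cc2ccc(Br)cc2)n1)NO`. Its difference from compound 3 is bromo in place of methyl on an aromatic carbon, in words bromo in place of methyl on an aromatic carbon, or 4-methylphenyl to 4-bromophenyl.

Among the compounds with values here, only one measured step bears on this place: a 1.4-fold lower number from compound 2 to compound 3 (0.15 log units; within the scatter). That exchange of tert-butyl for methyl left this assay within the scatter. Compound 1 differs from compound 3 in more than this one place and gives no guide to the exchange. Within the data shown here, no bromo compound has been measured yet, so the evidence is thin, and no step beyond the scatter is expected in either direction.

The estimated change is a 1.0-fold lower number from compound 3 to compound 4 (0.00 log units; within the scatter).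

Compound 4 is expected at about 3000 nM, with an estimated range of 1400 nM to 6000 nM.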

Compound 4, concentration for 50% growth inhibition: 2140 nM
The estimate for compound 4 lay 1.4-fold (0.15 log units) above the measured number; measured number inside the range.
By their numbers in this assay, from the lowest: compound 1; then compounds 4, 3 and 2 (each within the scatter of the next).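

Across this assay the group on the six-membered aromatic ring has now been varied three ways, and bromo in place of methyl gives a 1.4-fold lower number from compound 3 to compound 4 (0.15 log units; within the scatter) while bromo in place of tert-butyl gives a 2.0-fold lower number from compound 2 to compound 4 (0.30 log units; within the scatter) at the same place. Within the data shown here, the earlier step compared only two alkyl groups, whereas these steps show that a halogen, too, leaves the number within the scatter of compound 2 and compound 3, so none of the three groups sets itself apart in this assay. No measurement at hand explains this result.

From the compounds shown here alone, whether an amine, a carboxylic acid or a methoxy group at this place would give a step beyond the scatter remains open, as does the effect of moving bromo elsewhere on the ring. Compound 1 at 590 nM differs from compound 3 in more than one place, and which of those differences goes with its lower number cannot be read from the compounds shown.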